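A few compounds are considered here, and "the series" means these few. Any claim that something is new, unique, unknown or untested is made for them only; others in the source may bear on it.

Measured compounds and their numbers in an assay on HEK293 cells for displacement of a labelled ligand from corticotropin-releasing factor receptor 1 (Homo sapiens), read by scintillation proximity assay, with a stated time of 2 h; on this read-out higher numbers stand for weaker inhibition and lower numbers for stronger inhibition:
Compound 1 `CCCN(CCC)c1cccc2nc(Oc3c(OC)cc(COC)cc3OC)c(C)cc12`: 138 nM
Compound 2 `COCc1cc(OC)c(Oc2nc3cccc(N(CC4CCOCC4)CC4CC4)c3cc2C)c(OC)c1`: 762 nM
Compound 3 `CCN(CC1CCOCC1)c1cccc2nc(Oc3c(OC)cc(COC)cc3OC)c(C)cc12`: 646 nM

Compound 3 stands second highest of the three numbers. Its nearest neighbour is compound 2, where the difference is a 1.2-fold lower number from compound 2 to compound 3 (0.07 log units; within the scatter), a methyl in place of a cyclopropyl on a saturated chain carbon bound to the ring nitrogen. The furthest is compound 1: the step is a 4.7-fold higher number from compound 1 to compound 3 (0.67 log units; beyond the scatter), and the parallel step a 5.5-fold higher number from compound 1 to compound 2 (0.74 log units; beyond the scatter) shows that both amines built on an (oxan-4-yl)methyl group give weaker inhibition than dipropylamino.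

Compound 4 `COCc1cc(OC)c(Oc2nc3cccc(N(CC4CC4)C4CCOCC4)c3cc2C)c(OC)c1` carries the change ((cyclopropylmethyl)(oxan-4-yl)amino in place of ethyl((oxan-4-yl)methyl)amino on an aromatic carbon). For the measured compounds named here, no measured pair shows exactly this move of the oxane ring directly onto the nitrogen together with a cyclopropylmethyl. Going by the values given here, what bears on it is the pair of compounds 2 and 3, whose values lie within the scatter of each other, so exchanging ethyl for cyclopropylmethyl on this nitrogen gave no step; and the steps from compound 1 indicate that amines carrying the oxane stay in this weaker range. Compound 4 is therefore expected to sit close to compound 3, with a 1.1-fold higher number from compound 3 to compound 4 (0.03 log units; within the scatter), and the estimated value for compound 4 is 700 nM, between 250 nM and 2000 nM.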

Compound 4, half-maximal inhibitory concentration: 157 nM
For compound 4 the middle estimate is 4.5-fold (0.65 log units) above the measured one; the measured number lies below the stated range.
By their numbers in this assay, from the lowest: compounds 1 and 4 (each within the scatter of the next); then compounds 3 and 2 (each within the scatter of the next).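

In this assay the amine on the aromatic carbon of the shared core proves sensitive to how the oxane ring is attached: with cyclopropylmethyl kept on the nitrogen, oxan-4-yl in place of (oxan-4-yl)methyl gives a 4.9-fold lower number from compound 2 to compound 4 (0.69 log units; beyond the scatter) and so a step beyond the scatter, where the earlier compounds had shown no step on exchanging the other nitrogen substituent. The change from ethyl((oxan-4-yl)methyl)amino to (cyclopropylmethyl)(oxan-4-yl)amino gives a 4.1-fold lower number from compound 3 to compound 4 (0.61 log units; beyond the scatter) and so points the same way, although it alters both substituents at once and cannot by itself assign the gain to either. The oxane ring therefore does not hold an amine in the weaker range, since the comparison with dipropylamino gives a 1.1-fold higher number from compound 1 to compound 4 (0.06 log units; within the scatter) and stays within the scatter.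

Going by these compounds, whether ethyl(oxan-4-yl)amino would follow the same course, or whether a piperidin-4-yl group could stand in place of oxan-4-yl on this nitrogen, remains open. Nothing given here accounts for the effect of attaching the oxane ring directly to the nitrogen.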